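This account rests on a few compounds, and the source may have more. Where it says the series, first, only, none or still open, it means among the compounds named here.

Compound 2, the structure `N#Cc1c(N)nc(SCc2nnn[nH]2)c(C#N)c1-c1ccc(OCC2CC2)cc1`, is the starting point of this step. In an assay on CHO cells for displacement of a labelled ligand from adenosine receptor A1 (Homo sapiens), read by scintillation counting, with a stated time of 90 min, tested at 1 uM (a lower number here means less inhibition, a higher number more inhibition at the concentration tested (going by the name of the read-out)), compound 2 gives 3%. Compound 3, the structure `N#Cc1c(N)nc(SCC(N)=O)c(C#N)c1-c1ccc(OCC2CCC2)cc1`, gives 1% in this assay, and compound 1, the structure `N#Cc1c(N)nc(SCC(=O)NCO)c(C#N)c1-c1ccc(OCC2CC2)cc1`, gives 10%; all three numbers lie within the usual scatter of one another, so none of them can be set apart from the rest.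

The change to compound 4, the structure `COC(=O)CSc1nc(N)c(C#N)c(-c2ccc(OCC3CC3)cc2)c1C#N`, is methoxycarbonyl in place of 1H-tetrazol-5-yl on a saturated chain carbon bound to a sulfur. Going by the values given here, only one measured step touches the same place: a number 7 percentage points lower from compound 1 to compound 2 (within the scatter). That exchange of one group for another on the chain carbon bound to the sulfur left the number within the scatter. Among the compounds with values here, no measured step concerns the methoxycarbonyl group itself, so nothing beyond that one comparison bears on the change.

Compound 4 is therefore expected to stay within the scatter in this assay, with an estimated step of a number 2 percentage points higher from compound 2 to compound 4 (within the scatter). The estimated value for compound 4 is 5%, with a range from -5% to 15%.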

Compound 4, a percentage reported as inhibition, at one concentration (the size of the read-out at that concentration, not a potency): 23%
Compound 4: the middle estimate sits 18 percentage points below what was measured; the measured number lies above the stated range.
By their numbers in this assay, from the lowest: compounds 3, 2 and 1 (each within the scatter of the next); then compound 4.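

In this assay, the group on the saturated chain carbon bound to a sulfur now makes a difference beyond the scatter: methoxycarbonyl in place of 1H-tetrazol-5-yl gives a number 20 percentage points higher from compound 2 to compound 4 (beyond the scatter) while the earlier exchange at this place stayed within the scatter. Methoxy in place of (hydroxymethyl)amino on a carbonyl carbon gives a number 13 percentage points higher from compound 1 to compound 4 (beyond the scatter) and so shows that a change on the carbonyl carbon alone can also set compounds apart, although both steps are modest. No measured evidence is available to explain either step.

Going by these compounds, it remains open whether a carboxylic acid, an ethyl ester or a longer chain carrying the methoxycarbonyl group would match or exceed compound 4. Also open, on these data alone, is whether the methoxycarbonyl step would hold on the core of compound 3.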